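Aryl changes on the shared core: compound 3 to compound 4

The compounds below may be only part of what the source reports. "The series", "measured", "known", "first", "only" and "open" are said of these compounds alone.

The series keeps one core and varies the aryl group on the five-membered aromatic ring with 3 nitrogen. In a functional assay on the whole organism (plasma, strain Wistar) with Rattus norvegicus as the target, with a stated time of 15 days, at a dose of 100 mg/kg by the oral route (on this read-out lower numbers stand for a weaker effect and higher numbers for a stronger effect at the one dose given), compound 1 `O=C1NC(=O)/C(=C/c2ccc(OCCSc3nnc(-c4ccccc4)[nH]3)cc2)S1` gives 22.9%, compound 2 `O=C1NC(=O)/C(=C/c2ccc(OCCSc3nnc(Cc4ccccc4)[nH]3)cc2)S1` gives 34.4% and compound 3 `O=C1NC(=O)/C(=C/c2ccc(OCCSc3nnc(-c4ccccc4[N+](=O)[O-])[nH]3)cc2)S1` gives 26.8%. Compound 3 stands second highest of the three numbers; its nearest neighbour is compound 1, as a number 3.9 percentage points higher from compound 1 to compound 3 (within the scatter), and its furthest is compound 2, as a number 7.6 percentage points lower from compound 2 to compound 3 (within the scatter). Only a number 11.5 percentage points higher from compound 1 to compound 2 (beyond the scatter) lies beyond the scatter.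

Compound 4 `O=C1NC(=O)/C(=C/c2ccc(OCCSc3nnc(-c4ccc(Cl)cc4)[nH]3)cc2)S1` differs from compound 3 by 4-chlorophenyl in place of 2-nitrophenyl on an aromatic carbon. The step bearing most on this is a number 3.9 percentage points higher from compound 1 to compound 3 (within the scatter), which shows that removing or adding the nitro group hardly moves this assay. Going by the values given here, a chlorine on the aryl ring has no precedent here, and the only step beyond the scatter concerns benzyl against phenyl, not a ring substituent. No step beyond the scatter is therefore expected, and compound 4 is estimated at 25%, between 13% and 37%, meaning an expected a number 1.8 percentage points lower from compound 3 to compound 4 (within the scatter).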

Compound 4, a percentage reported as activity, at one dose (the size of the read-out at that dose, not a potency): 28.9%
Beside the measured number, compound 4's estimate is 3.9 percentage points below it, and the stated range covers the measured number.
By their numbers in this assay, from the lowest: compounds 1, 3, 4 and 2 (each within the scatter of the next, the first and the last beyond it).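

At this position, on an aromatic carbon between two ring nitrogen atoms, exchanging 2-nitrophenyl for 4-chlorophenyl gives a number 2.1 percentage points higher from compound 3 to compound 4 (within the scatter) in this assay, so these two substituted phenyl groups cannot be told apart here. Chloro on the phenyl ring gives a number 6 percentage points higher from compound 1 to compound 4 (within the scatter) as well, and the change from benzyl gives a number 5.5 percentage points lower from compound 2 to compound 4 (within the scatter), which places compound 4 within the scatter of both compound 1 and compound 2, although those two lie beyond the scatter of each other. No measurement on hand accounts for these small steps.

From the compounds shown here alone, it remains open whether a phenyl ring carrying an amine or a carboxylic acid would give a step beyond the scatter from compound 1. Also open, going by these compounds, is whether a longer chain, such as phenethyl, or chloro on the benzyl ring of compound 2 would separate from compound 2.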